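Permeability notes: piperazinyl for piperidinyl on the chain

The source may report more compounds than this note shows. Statements on the series, on what has been measured and on what is new or still open speak of the compounds shown alone.

Measured in an ADME assay for permeability, using PAMPA, with a stated time of 4 h, at pH 7.4; a higher number here means that the compound crosses the layer faster, a lower number that the compound crosses the layer more slowly:
compound 1 `c1ccc2c(c1)CN[C@@H](CN(CC[C@H]1CCCNC1)[C@H]1CCCc3cccnc31)C2` gives 55 nm/s
compound 2 `c1cnc(CN(CCCN2CCNCC2)[C@H]2CCCc3cccnc32)nc1` gives 31 nm/s
compound 3 `c1ccc2c(c1)CN[C@H](CN(CCCN1CCNCC1)[C@H]1CCCc3cccnc31)C2` gives 16 nm/s

Compound 1 gives the largest of the three numbers in this assay, but compound 2 cannot be separated from it within the scatter; only compound 3 stands beyond the scatter of compound 1.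

Compound 4 `c1ccc2c(c1)CN[C@@H](CN(CCN1CCNCC1)[C@H]1CCCc3cccnc31)C2` is not yet measured. It differs from compound 1 in one place: piperazin-1-yl in place of piperidin-3-yl on a saturated chain carbon, two bonds along the chain from an amine nitrogen.

Among the compounds with values here, the only step measured so far, a 1.9-fold lower number from compound 2 to compound 3 (0.29 log units; within the scatter), changes the group on the other chain and not the ring in question, so it does not bear directly on this change. Both compound 2 and compound 3 carry piperazin-1-yl on the chain, and both give lower numbers than compound 1; compound 3 also shares the tetrahydroisoquinolinyl arm of compound 4. On that basis a lower number is expected for compound 4, likely beyond the scatter, a 2.3-fold lower number from compound 1 to compound 4 (0.36 log units; beyond the scatter). Compound 4 is therefore estimated at 24 nm/s, with a range from 11 nm/s to 50 nm/s.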

Compound 4, apparent permeability: 10 nm/s
Compound 4: the middle estimate sits 2.4-fold (0.38 log units) above what was measured; the measured number lies below the stated range.
By their numbers in this assay, from the lowest: compounds 4, 3, 2 and 1 (each within the scatter of the next, the first and the last beyond it).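

In this assay, within the data shown here, this is the first direct reading of the ring change on this chain, and it gives a 5.5-fold lower number from compound 1 to compound 4 (0.74 log units; beyond the scatter) with the rest of compound 1 held in place. The step therefore belongs to the exchange of piperidin-3-yl for piperazin-1-yl on a saturated chain carbon, two bonds along the chain from an amine nitrogen, where the entering ring has two hetero atoms, the leaving ring has one, and the heavy-atom count stays the same. No measurement at hand bears on what lies behind the step.

Still open, as far as these compounds go, is whether the step follows the second ring nitrogen or the change of attachment from ring carbon to ring nitrogen, which piperidin-1-yl on the same chain could separate. Also open, from the compounds shown here alone, is whether a 4-methylpiperazin-1-yl group or a longer chain would give a step of similar size.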